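Swapping One Five-Membered Ring on Compound 2

The source may hold more compounds than are shown below. What is called first, only, known or untested is meant among the compounds shown, and "the series" means these compounds.

Three compounds built on one shared core were tested in an assay on isolated protein for inhibition of ubiquitin carboxyl-terminal hydrolase 7 (Homo sapiens), with stated times of 30 min and 2 h; a higher number here means a weaker inhibitor, a lower number a stronger inhibitor. Compound 1 `CC(C)NCc1ccc(-c2c3ncn(CC4(O)CCN(Cc5ccc(-c6ccco6)cc5Cl)CC4)c(=O)c3nn2C)cc1` gives 29.1 nM. Compound 2 `Cn1nc2c(=O)n(CC3(O)CCN(Cc4ccc(-c5ccsc5)cc4Cl)CC3)cnc2c1-c1ccc(CN)cc1` gives 59.5 nM, the second highest of the three numbers, with compound 1 nearest and compound 3 furthest. Compound 3 `Cn1nc2c(=O)n(CC3(O)CCN(Cc4ccc(-c5ccco5)cc4Cl)CC3)cnc2c1-c1ccc(CNC(=O)C(F)(F)F)cc1` gives 2060 nM. For the measured compounds named here, the only single-place step measured is a 71-fold higher number from compound 1 to compound 3 (1.85 log units; beyond the scatter), a large loss of potency. Compound 4 `Cn1cc(-c2ccc(CN3CCC(O)(Cn4cnc5c(-c6ccc(CN)cc6)n(C)nc5c4=O)CC3)c(Cl)c2)cn1` differs from compound 2 by 1-methyl-1H-pyrazol-4-yl in place of thiophen-3-yl on an aromatic carbon. Going by the values given here, no measured step alters this ring alone: the step from compound 1 to compound 3 sits on the amine nitrogen, and compounds 1 and 2 differ at the ring but also elsewhere. Compound 4 is therefore expected to give about 60 nM, between 20 nM and 180 nM. That estimate means an expected step of a 1.0-fold higher number from compound 2 to compound 4 (0.00 log units; within the scatter), within scatter.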

Compound 4, half-maximal inhibitory concentration: 291 nM
Estimate against measurement, compound 4: 4.9-fold (0.69 log units) below; the whole stated range lies below it.
By their numbers in this assay, from the lowest: compound 1; then compound 2; then compound 4; then compound 3.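

For the compounds shown here, this is the first step that changes only the five-membered ring on this aromatic carbon, meta to the chloro group, and it shows that the position is sensitive to which ring it carries: in this assay, 1-methyl-1H-pyrazol-4-yl in place of thiophen-3-yl gives a 4.9-fold higher number from compound 2 to compound 4 (0.69 log units; beyond the scatter). The entering ring differs in both its hetero atoms and its added methyl, and this single step cannot separate the two. Nothing measured here explains the weaker inhibition. From the compounds shown here alone, it remains open whether a 1H-pyrazol-4-yl ring without the methyl, or a plain phenyl ring, would give a number closer to that of compound 2 or compound 4.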